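Methoxy in place of isopropyl on the biphenyl arm

The source may report more compounds than this note shows. Statements on the series, on what has been measured and on what is new or still open speak of the compounds shown alone.

Within the data shown here, compound 3 `CC(C)c1ccccc1-c1cccc(COc2ccc(S(=O)(=O)CC(=O)O)cc2)c1` gives 74.1 nM in a functional assay on CHO cells for agonist activity at Free fatty acid receptor 1 (Homo sapiens), read by FLIPR and calcium flux (on this read-out higher numbers stand for an effect only at larger amounts of compound and lower numbers for an effect already at smaller amounts), the lowest of the three numbers measured so far. Compound 1 `O=C(O)CS(=O)(=O)c1ccc(OCc2cccc(-c3ccccc3)c2)cc1` gives 288 nM and compound 2 `O=C(O)CS(=O)(=O)c1ccc(OCc2cccc(-c3ccccc3F)c2)cc1` gives 257 nM; the step of a 1.1-fold lower number from compound 1 to compound 2 (0.05 log units; within the scatter) stays within the scatter, whereas a 3.9-fold lower number from compound 1 to compound 3 (0.59 log units; beyond the scatter) and a 3.5-fold lower number from compound 2 to compound 3 (0.54 log units; beyond the scatter) both lie beyond it. Compound 4 `COc1ccccc1-c1cccc(COc2ccc(S(=O)(=O)CC(=O)O)cc2)c1` differs from compound 3 in one place: methoxy in place of isopropyl on an aromatic carbon. Among the measured compounds shown here, no measured step puts a methoxy on that carbon. The two steps that bear on the change are the ones that introduced the isopropyl, a 3.9-fold lower number from compound 1 to compound 3 (0.59 log units; beyond the scatter) and a 3.5-fold lower number from compound 2 to compound 3 (0.54 log units; beyond the scatter); they show that this carbon is sensitive to what sits on it, and that hydrogen and fluoro there give numbers close to each other. Since methoxy has not been tested, part of the gain seen with isopropyl is expected to be lost, so a modest step towards a higher number, a 2.0-fold higher number from compound 3 to compound 4 (0.31 log units; beyond the scatter), is expected for compound 4. The estimate for compound 4 is 150 nM, in the range 60 nM to 400 nM.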

Compound 4, half-maximal effective concentration: 195 nM
Beside the measured number, compound 4's estimate is 1.3-fold (0.11 log units) below it; low and high end bracket the measured number.
By their numbers in this assay, from the lowest: compound 3; then compounds 4, 2 and 1 (each within the scatter of the next).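

In this assay, methoxy does not reproduce the gain seen with isopropyl on this aromatic carbon (a 2.6-fold higher number from compound 3 to compound 4 (0.42 log units; beyond the scatter)), a step beyond the scatter, so that gain does not extend to every group placed there. The steps to the other two compounds stay within the scatter (a 1.5-fold lower number from compound 1 to compound 4 (0.17 log units; within the scatter); a 1.3-fold lower number from compound 2 to compound 4 (0.12 log units; within the scatter)), so hydrogen, fluoro and methoxy cannot be told apart here, and among these four compounds only the 2-isopropylphenyl arm stands clear of the rest. Nothing on hand gives a reason for this separation.

Going by these compounds, whether ethyl, tert-butyl or cyclopropyl on this carbon would stay with isopropyl, or a hydroxyl or an amine would stay with methoxy, remains open. Also open, on these data alone, is how isopropyl would read on another carbon of the same ring.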